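Methyl on the fused ring of compound 2: expected inhibition

The compounds below may be only part of what the source reports. "The series", "measured", "known", "first", "only" and "open" are said of these compounds alone.

Measured so far in an in vitro assay on P815B cells for inhibition of Indoleamine 2,3-dioxygenase 1 (Mus musculus), tested at 20 uM; on this read-out higher numbers stand for more inhibition at the one concentration tested (going by the name of the read-out) and lower numbers for less inhibition:
compound 1 `O=C(Cc1ccncc1)c1cc2ccccc2[nH]1`: "not active" (no number reported)
compound 2 `O=C(Cc1cccnc1)c1cc2ccccc2[nH]1`: 13%
compound 3 `O=C(Cc1ccccn1)c1cc2ccccc2[nH]1`: 10%

Compound 1 is reported in this assay only as "not active" (no number reported), without a number. Going by the values given here, compound 2 gives 13% and compound 3 gives 10%; the step of a number 3 percentage points lower from compound 2 to compound 3 (within the scatter) lies within the scatter, so the two numbers cannot be told apart, and compound 2 stands alongside compound 3 rather than above it, with compound 1 as the one entry lacking a number.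

Compound 4 `Cc1ccc2[nH]c(C(=O)Cc3cccnc3)cc2c1` is not yet measured. Relative to compound 2 the change is methyl in place of hydrogen on an aromatic carbon.

Among the compounds with values here, none of the measured steps touches the same place: the one step recorded, a number 3 percentage points lower from compound 2 to compound 3 (within the scatter), moves a ring nitrogen on the other part of the molecule and is itself within the scatter. Within the data shown here, there is thus no step that speaks for a shift in either direction, and with a single carbon entering at the fused ring no step beyond the scatter is expected.

Compound 4 is therefore estimated at 13%, with a range from 0% to 28%, which means an expected step of no change at the digits printed from compound 2 to compound 4 (within the scatter).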

Compound 4, a percentage reported as inhibition, at one concentration (the size of the read-out at that concentration, not a potency): 21%
Compound 4: middle estimate off by 8 percentage points, on the low side, and the stated range covers the measured number.
By their numbers in this assay, from the lowest: compounds 3, 2 and 4 (each within the scatter of the next, the first and the last beyond it).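

In this assay, the fused system gets its first test of substitution: methyl in place of hydrogen on this aromatic carbon, meta to one fused ring and para to the other, gives a number 8 percentage points higher from compound 2 to compound 4 (within the scatter). The earlier step concerned only the ring nitrogen on the other part of the molecule, so the series had shown nothing about this part of the shared core until now. At this one position and with this one carbon, the read-out therefore stays within the scatter of the parent, so a methyl here is accepted without a measurable loss, though it gives no demonstrated gain either. The compounds shown offer no measurement that could account for the step.

Still open, on these data alone, is whether a group other than methyl at this carbon, such as chlorine, methoxy, an amine or a longer chain, would move the read-out beyond the scatter. Also open, as far as these compounds go, is whether methyl at other aromatic carbons of the fused system, or the same methyl combined with the pyridin-2-yl group of compound 3, would behave as compound 4 does.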